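The compounds below may be only part of what the source reports. "The series", "measured", "known", "first", "only" and "open" are said of these compounds alone.

Measured compounds in an assay on isolated protein for antagonist activity at Bile acid receptor (Homo sapiens), read by HTRF, with a stated time of 30 min; a higher number here means a weaker inhibitor, a lower number a stronger inhibitor:

Compound 1, `CCCCc1cc(CC)c(O)cc1OCCCCCC(C)(C)c1nnn[nH]1`: compound 1 gives 8700 nM.
Compound 2, `CCc1cc(C(C)=O)c(OC2CCCC2)cc1OCCCCCC(C)(C)c1nnn[nH]1`: compound 2 gives 3300 nM.
Compound 3, `CCCc1cc(C(C)=O)c(O)cc1OCCCCCC(C)(C)c1nnn[nH]1`: compound 3 gives 25200 nM.

Compound 3 stands at the highest number of the three, so it is the weakest inhibitor in this set; its nearest neighbour is compound 1, whose value is lower by a margin beyond the scatter, and compound 2 lies furthest from it, lower still. Going by the values given here, no two of the measured compounds differ in one place only, so no single-point step is available as a guide.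

Compound 4, `CC(=O)c1cc(CC(C)C)c(OCCCCCC(C)(C)c2nnn[nH]2)cc1O`, differs from compound 3 by methyl in place of hydrogen on a saturated chain carbon bound to two saturated chain carbons. This is a small enlargement of a chain, and nothing in the measured set isolates the effect of such an addition. The step from compound 3 to compound 4 in this assay is expected to be modest, and could fall within the scatter; a small move toward a stronger inhibitor is estimated as a 1.6-fold lower number from compound 3 to compound 4 (0.20 log units; within the scatter). For compound 4 the estimated value is 16000 nM, in a range from 6000 nM to 40000 nM.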

Compound 4, half-maximal inhibitory concentration: 5800 nM
For compound 4 the middle estimate is 2.8-fold (0.44 log units) above the measured one; the whole stated range lies above it.
By their numbers in this assay, from the lowest: compounds 2, 4 and 1 (each within the scatter of the next, the first and the last beyond it); then compound 3.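

In this assay, going by these compounds alone, the change from propyl to isobutyl gives a 4.3-fold lower number from compound 3 to compound 4 (0.64 log units; beyond the scatter) and provides the first comparison that differs in one place. At this position, a methyl in place of hydrogen on a saturated chain carbon bound to two saturated chain carbons therefore moves the number beyond the usual scatter, toward a stronger inhibitor. No measured evidence at hand accounts for this shift.

On these data alone, it remains open whether a neopentyl group or a longer chain at this position would extend the shift or reverse it, and whether an amine or a hydroxyl on the chain would be accepted. Within the data shown here, the single pair also leaves open whether the same methyl gives a similar step when other parts of the shared core differ.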